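The compounds below may be only part of what the source reports. "The series", "measured", "known", "first", "only" and "open" are said of these compounds alone.

Measured compounds:
- compound 1, `CC1CCCCC1C(=O)N1CC(c2nc(-c3cccc(F)c3)no2)C1`: > 10000 nM
- compound 2, `O=C(c1ccccc1F)N1CC[C@H]1c1nc(-c2cccc(F)c2)no1`: 920 nM
- compound 3, `CC1CCC(C(=O)N2CC(c3nc(-c4cccc(Cl)c4)no3)C2)CC1`: > 10000 nM

In an assay on HEK293 cells for negative allosteric modulation of metabotropic glutamate receptor 5 (Homo sapiens), read by FLIPR (on this read-out higher numbers stand for weaker inhibition and lower numbers for stronger inhibition), compound 3 gives no number, only a limit, > 10000 nM. Compound 1 likewise gives only a limit, > 10000 nM. Two of the three values shown therefore sit at the limit of > 10000 nM in this assay, at which 2 of the 3 values shown sit, and compound 3 stands there with no measurable inhibition. Going by the values given here, the one number in the set comes from compound 2, which in this assay gives 920 nM; its carbonyl carries an aromatic ring rather than a saturated one, as its structure shows.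

Compound 4, `O=C(c1cccc(F)c1)N1CC(c2nc(-c3cccc(Cl)c3)no2)C1`, differs from compound 3 in one place: 3-fluorophenyl in place of 4-methylcyclohexyl on a carbonyl carbon. Among the compounds with values here, the amide part of compound 4 thus resembles that of compound 2 more than that of compound 3 or compound 1, though the other parts of the molecules are not the same, and no direct step between measured compounds covers this change.

Expectation: a move from the limit to a measurable number, that is toward stronger inhibition, is expected, with the step from compound 3 to compound 4 estimated as an at least 4.0-fold lower number from compound 3 to compound 4 (0.60 log units; beyond the scatter). For compound 4 the estimate in this assay is 2500 nM, with a range from 500 nM to 10000 nM.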

Compound 4, half-maximal inhibitory concentration: 780 nM
Beside the measured number, compound 4's estimate is 3.2-fold (0.51 log units) above it; measured number inside the range.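

On a carbonyl carbon whose other neighbours are an amide-type nitrogen in a ring, 3-fluorophenyl in place of 4-methylcyclohexyl gives an at least 12-fold lower number from compound 3 to compound 4 (1.10 log units; beyond the scatter) in this assay. Going by these compounds alone, this is the first single-place comparison, and it ties measurable inhibition to this position: a six-membered non-aromatic ring gives way to a six-membered aromatic ring, with no hydrogen-bond donors or acceptors on either group. The step has only a lower bound, since the value of compound 3 is a limit and not a number: the limit of > 10000 nM in this assay, at which 2 of the 4 values shown sit.

Going by these compounds, how much of the step belongs to the aromatic ring and how much to its fluorine remains open. A plain phenyl on this carbonyl would separate the two, and a pyridine ring would test whether the ring must be carbon only.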